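The source may report more compounds than this note shows. Statements on the series, on what has been measured and on what is new or still open speak of the compounds shown alone.

In a physicochemical assay, with a stated time of 6 min (on this read-out higher numbers stand for weaker inhibition and lower numbers for stronger inhibition), compound 1 (`COc1ccc(NC(=O)Nc2nc(-c3cc4cc([N+](=O)[O-])ccc4o3)cs2)cc1`) gives 121000 nM, and compound 2 (`O=C(Nc1ccc(Cl)cc1)Nc1nc(-c2cc3cc([N+](=O)[O-])ccc3o2)cs1`) gives 117000 nM. These two numbers lie within the usual scatter of repeated measurements, so compound 2 cannot be told apart from compound 1, and neither can be called the stronger inhibitor.

The next structure, compound 3 (`O=C(Nc1ccc(F)cc1)Nc1nc(-c2cc3cc([N+](=O)[O-])ccc3o2)cs1`), keeps the shared core and differs from compound 2 in a single substituent: fluoro in place of chloro on an aromatic carbon. This is fluoro in place of chloro on an aromatic carbon, para to a large group, which turns 4-chlorophenyl into 4-fluorophenyl.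

For the measured compounds named here, only one measured step bears on this change, and it falls at the same place on the ring: chloro in place of methoxy gave a 1.0-fold lower number from compound 1 to compound 2 (0.01 log units; within the scatter). Going by the values given here, one step is thin evidence, and no fluoro compound has been measured yet. Even so, nothing in the data points to a step beyond the scatter in this assay, in either direction.

The estimated change is a 1.0-fold lower number from compound 2 to compound 3 (0.01 log units; within the scatter). Compound 3 is expected to give about 115000 nM, with an estimated range from 60000 nM to 220000 nM.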

Compound 3, half-maximal inhibitory concentration: 123000 nM
For compound 3 the middle estimate is 1.1-fold (0.03 log units) below the measured one, and the stated range covers the measured number.
By their numbers in this assay, from the lowest: compounds 2, 1 and 3 (each within the scatter of the next).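

In this assay, putting fluoro in place of chloro gives a 1.1-fold higher number from compound 2 to compound 3 (0.02 log units; within the scatter), and putting fluoro in place of methoxy gives a 1.0-fold higher number from compound 1 to compound 3 (0.01 log units; within the scatter) as well. For the compounds shown here, the earlier compounds offered only a single comparison at this place on the aromatic ring, para to a large group, whereas three different groups can now be set side by side, and methoxy, chloro and fluoro cannot be told apart on this read-out. No measurement on hand gives a reason for this flat result.

An amine, a carboxylic acid or a longer chain at the same place might read differently or might read just the same, and the compounds shown do not settle which. They also leave open whether a change elsewhere on the shared core, rather than on this ring, would move the number beyond the usual scatter.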